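Paw edema series: thiophen-2-yl in place of 4-chlorophenyl

A few compounds are considered here, and "the series" means these few. Any claim that something is new, unique, unknown or untested is made for them only; others in the source may bear on it.

Measured compounds:
compound 1 `CS(=O)(=O)c1ccc(C2=NN(c3ccc(C(=O)O)cc3)C(c3ccccc3)C2)cc1`, 56.4%
compound 2 `CS(=O)(=O)c1ccc(C2=NN(c3ccc(C(=O)O)cc3)C(c3ccc(F)cc3)C2)cc1`, 42.3%
compound 3 `CS(=O)(=O)c1ccc(C2=NN(c3ccc(S(N)(=O)=O)cc3)C(c3ccc(Cl)cc3)C2)cc1`, 42.4%

In a functional assay on the whole organism for inhibition, with Rattus norvegicus as the target, read by paw edema, with a stated time of 3 h, at a dose of 50 mg/kg by the oral route (a higher number here means more inhibition at the dose given (going by the name of the read-out), a lower number less inhibition), compound 3 gives 42.4%, second highest of the three numbers; its gap to compound 2 lies within the scatter, its gap to compound 1 beyond it. Compound 4 `CS(=O)(=O)c1ccc(C2=NN(c3ccc(S(N)(=O)=O)cc3)C(c3cccs3)C2)cc1` differs from compound 3 in one place: thiophen-2-yl in place of 4-chlorophenyl on a saturated ring carbon. Going by the values given here, the only measured step at the group on this saturated ring carbon is a number 14.1 percentage points lower from compound 1 to compound 2 (beyond the scatter), a modest drop; no measured step swaps the whole ring there. A step of similar or smaller size is therefore expected, with no clear direction: the estimated step is a number 1.6 percentage points higher from compound 3 to compound 4 (within the scatter), not beyond the scatter. Compound 4 is expected to give 44%, in the range 30% to 58%.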

Compound 4, a percentage reported as inhibition, in the whole organism at one dose (the size of the read-out at that dose, not a potency): 36.4%
Compound 4: the middle estimate sits 7.6 percentage points above what was measured, within the range that was stated.
By their numbers in this assay, from the lowest: compounds 4, 2 and 3 (each within the scatter of the next); then compound 1.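

In this assay, the step of a number 6 percentage points lower from compound 3 to compound 4 (within the scatter) shows that, with a 4-sulfamoylphenyl group on the ring, a whole-ring swap on this saturated ring carbon, from a six-membered carbon ring to thiophen-2-yl, stays within the usual scatter. No measurement here bears on the reason for this result.

As far as these compounds go, how a pyridin-2-yl or cyclohexyl group would read at this carbon remains open. So does whether thiophen-2-yl gives a similar step in the carboxylic acid series of compound 1.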